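A few compounds are considered here, and "the series" means these few. Any claim that something is new, unique, unknown or untested is made for them only; others in the source may bear on it.

Working notes on the series. In an assay on CHO-K1 cells for displacement of a labelled ligand from prostaglandin E2 receptor EP1 subtype (Homo sapiens) (a higher number here means a weaker inhibitor, a lower number a stronger inhibitor), compound 1 `Cc1cc(C(=O)NCc2ccccn2)nn1Cc1cc(Cl)ccc1OCc1ccccc1` gives 25.1 nM, compound 2 `Cc1cc(C(=O)NCc2cccnc2)nn1Cc1cc(Cl)ccc1OCc1ccccc1` gives 50.1 nM, and compound 3 `Cc1cc(NC(=O)C2CCCO2)nn1Cc1cc(Cl)ccc1OCc1ccccc1` gives 39.8 nM. Compound 3 sits with the other two without separation: one step is a 1.3-fold lower number from compound 2 to compound 3 (0.10 log units; within the scatter) and another is a 1.6-fold higher number from compound 1 to compound 3 (0.20 log units; within the scatter), both inside the scatter, as is a 2.0-fold higher number from compound 1 to compound 2 (0.30 log units; within the scatter).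

Compound 4 `COC(=O)Nc1cc(C)n(Cc2cc(Cl)ccc2OCc2ccccc2)n1` differs from compound 3 at the carbonyl carbon: methoxy in place of oxolan-2-yl on a carbonyl carbon. For the measured compounds named here, no measured step in this assay touches the group on that carbonyl carbon; the steps so far swap the pyridinyl position or turn the amide around, and none of them moved the number beyond the scatter. There is therefore nothing in this set to argue for a shift in either direction, and the expectation is a number for compound 4 close to that of compound 3.

The expected step is a 1.1-fold higher number from compound 3 to compound 4 (0.05 log units; within the scatter), in this assay. Compound 4 is estimated at 45 nM, with a range from 15 nM to 150 nM.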

Compound 4, half-maximal inhibitory concentration: 200 nM
Compound 4: middle estimate off by 4.4-fold (0.65 log units), on the low side; measured number outside the range, above it.
By their numbers in this assay, from the lowest: compounds 1, 3 and 2 (each within the scatter of the next); then compound 4.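

In this assay, for the compounds shown here, the group on the carbonyl carbon is the first change in the set to move the number beyond the scatter: methoxy in place of oxolan-2-yl gives a 5.0-fold higher number from compound 3 to compound 4 (0.70 log units; beyond the scatter). The (methoxycarbonyl)amino group also separates from both carbamoyl groups, with a 4.0-fold higher number from compound 2 to compound 4 (0.60 log units; beyond the scatter) and an 8.0-fold higher number from compound 1 to compound 4 (0.90 log units; beyond the scatter), whereas ((oxolan-2-yl)carbonyl)amino stayed within the scatter of both. No measurement in hand accounts for this shift.

The compounds shown do not separate the departure of the five-membered ring from the arrival of the methoxy oxygen on the carbonyl carbon. A methyl, a cyclopentyl or a dimethylamino group on that carbonyl carbon would bear on this question.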